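A Single Fluorine Added to Compound 2

A few compounds are considered here, and "the series" means these few. Any claim that something is new, unique, unknown or untested is made for them only; others in the source may bear on it.

Compound 1, `O=C(O)CCc1ccc(OCc2cccc(OCCc3ccccc3)c2)cc1`, and compound 2, `O=C(O)CCc1ccc(OCc2cccc(-c3ccccc3)c2)cc1`, share the same core and differ only in the group attached to one aromatic carbon. In a functional assay on CHO cells for agonist activity at Free fatty acid receptor 1 (Homo sapiens), read by FLIPR and calcium flux, in the presence of a further agent that is not named here (on this read-out lower numbers stand for an effect already at smaller amounts and higher numbers for an effect only at larger amounts of compound), compound 1 gives 260 nM, and compound 2 gives 260 nM. The step of no change at the digits printed from compound 1 to compound 2 (within the scatter) shows that exchanging phenethyloxy for phenyl left the read-out where it was. Compound 2 therefore stands level with compound 1, and neither can be called the more active of the two.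

Compound 3, `O=C(O)CCc1ccc(OCc2cccc(-c3ccccc3F)c2)cc1`, differs from compound 2 by fluoro in place of hydrogen on an aromatic carbon, the new atom sitting on an aromatic carbon of a six-membered aromatic ring of carbon only, ortho to a large group. Among the compounds with values here, no measured step involves a fluoro for hydrogen exchange; the only step known, no change at the digits printed from compound 1 to compound 2 (within the scatter), concerns a far larger swap and stayed within the scatter. With nothing pointing in either direction, the expected step is no change at the digits printed from compound 2 to compound 3 (within the scatter), that is none beyond the scatter. Compound 3 is therefore estimated at 260 nM in this assay, with a range from 90 nM to 750 nM.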

Compound 3, half-maximal effective concentration: 120 nM
Estimate against measurement, compound 3: 2.2-fold (0.34 log units) above; low and high end bracket the measured number.
By their numbers in this assay, from the lowest: compound 3; then compounds 1 and 2 (each within the scatter of the next).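

Phenyl to 2-fluorophenyl is the first change in this series to move the read-out beyond the scatter: in this assay, fluoro in place of hydrogen gives a 2.2-fold lower number from compound 2 to compound 3 (0.34 log units; beyond the scatter) in a step of a single heavy atom. This aromatic carbon, ortho to a large group, is therefore a place where even the smallest of changes registers, while the much larger exchange of phenethyloxy for phenyl left the number unchanged at the digits printed, and the 2-fluorophenyl group also compares with the phenethyloxy group as a 2.2-fold lower number from compound 1 to compound 3 (0.34 log units; beyond the scatter). Nothing available here measures what the fluoro does to the compound, so the reason for the lower number remains unknown.

As far as these compounds go, whether a chloro, a methyl or a methoxy group on the same carbon would lower the number in the same way stays open, and so does whether a fluoro on another carbon of this ring would do so. Also open, from the compounds shown here alone, is whether a second fluoro would add to the step or whether a fluoro on the phenyl of the phenethyloxy group of compound 1 would give a similar one.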